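The source may report more compounds than this note shows. Statements on the series, on what has been measured and on what is new or still open speak of the compounds shown alone.

The measured compounds, all in an assay on HEK293 cells for displacement of a labelled ligand from Type-2 angiotensin II receptor (Homo sapiens), tested at 1 uM; a lower number here means a weaker effect, a higher number a stronger effect of the compound at the concentration tested:

Compound 1, `CC[C@H](C)[C@H](NC(=O)c1cccc(Cn2ccnc2)c1)C(=O)NNS(=O)(=O)c1c(C)cc(C)cc1C`, gives 10%.
Compound 2, `CC[C@H](C)[C@H](NC(=O)c1cccc(Cn2ccnc2)c1)C(=O)Nc1nccs1`, gives 4%.
Compound 3, `CC[C@H](C)[C@H](NC(=O)c1cccc(Cn2ccnc2)c1)C(=O)NNS(=O)(=O)c1ccc(OC)cc1`, gives 3%.

The three numbers are close. Compound 2 differs from compound 1 and from compound 3 by amounts within the scatter, so the three compounds cannot be told apart on these results; all of them show little displacement in this assay.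

Within the data shown here, the one measured step, a number 7 percentage points lower from compound 1 to compound 3 (within the scatter), exchanges one group on a sulfonyl sulfur and changes nothing beyond the scatter.

Compound 4, `CC[C@H](C)[C@H](NC(=O)c1cccc(Cn2ccnc2)c1)C(=O)NO`, shares the core of compound 2 and differs from it in one place: hydroxy in place of 1,3-thiazol-2-yl on an amide-type nitrogen. Among the measured compounds shown here, no measured step touches the group on this amide-type nitrogen, and the two compounds that carry a sulfonyl hydrazide instead of an aryl amide at that end, compound 1 and compound 3, are not separated from compound 2 beyond the scatter either. For the measured compounds named here, every result so far is low, and the only measured step is flat.

On that basis no step beyond the scatter is expected from compound 2 to compound 4 in this assay, the expected step being a number 1 percentage points higher from compound 2 to compound 4 (within the scatter). Compound 4 is estimated to give 5%, with a range from 0% to 15%.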

Compound 4, a percentage reported as inhibition, at one concentration (the size of the read-out at that concentration, not a potency): "not active" (no number reported)
No number was reported for compound 4, and the estimate cannot be compared.
By their numbers in this assay, from the lowest: compounds 3, 2 and 1 (each within the scatter of the next).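

In this assay, among these compounds, compound 4 is reported as "not active" without a number, so no step from compound 2 to compound 4 can be read. The compounds shown leave open whether any group on the amide-type nitrogen can raise the read-out beyond the scatter of these low results. No measurement shown offers an explanation for the result for compound 4.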